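The source may report more compounds than this note shows. Statements on the series, on what has been measured and on what is new or still open speak of the compounds shown alone.

Measured so far:
compound 1, `CCCC/C=C\CCCCCCCCCc1cc(=O)c2c(O)cc(O)c(C)c2o1`: 17500 nM
compound 2, `CC/C=C\C/C=C\C/C=C\CCCCCCCc1cc(=O)c2c(O)c(C)c(O)c(C)c2o1`: 17500 nM
compound 3, `CC/C=C\C/C=C\C/C=C\CCCCCCCc1cc(=O)c2c(O)cc(O)c(C)c2o1`: 17500 nM

In a functional assay on MCF7 cells (Homo sapiens) for antiproliferative activity, read by MTT assay (a lower number here means a stronger inhibitor, a higher number a weaker inhibitor), compound 3 gives 17500 nM, and this is level with compound 1 and compound 2 at the digits shown. Compound 4, `CC/C=C\C/C=C\C/C=C\CCCCCCCc1cc(=O)c2c(O)cc(OCOC)c(C)c2o1`, differs from compound 3 by methoxymethyl in place of hydrogen on an oxygen on an aromatic ring. Two measured steps lead into compound 3: no change at the digits printed from compound 1 to compound 3 (within the scatter) and no change at the digits printed from compound 2 to compound 3 (within the scatter), and neither moved the number beyond the scatter. Among the measured compounds shown here, both concern the chain or a methyl on the ring; no measured step touches an oxygen on an aromatic ring, so they bear on the new change only loosely. With nothing pointing either way, the step of a 1.1-fold higher number from compound 3 to compound 4 (0.06 log units; within the scatter) is expected to stay within the scatter. Compound 4 is therefore estimated at 20000 nM, within a range from 7000 nM to 55000 nM.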

Compound 4, half-maximal inhibitory concentration: 17500 nM
Estimate against measurement, compound 4: 1.1-fold (0.06 log units) above, within the range that was stated.
By their numbers in this assay, from the lowest: compounds 1, 2, 3 and 4 (each within the scatter of the next).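

In this assay, among the compounds shown here, the step gives the first reading at an oxygen on an aromatic ring: methoxymethyl in place of hydrogen gives no change at the digits printed from compound 3 to compound 4 (within the scatter). So, for this pair, the hydrogen on this oxygen can be replaced by this group with no change beyond the scatter. No measurement here offers an explanation for this result.

Still open, going by these compounds, is how a bulkier group on this oxygen, such as benzyl or a chain bearing an amine, would read. Also open, on these data alone, is whether the same change at the other hydroxy would read alike.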